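Replacing (trifluoromethyl)sulfanyl with amino in compound 3

The compounds below may be only part of what the source reports. "The series", "measured", "known", "first", "only" and "open" are said of these compounds alone.

Compound 1 `CC(=O)c1ccc(NC(=O)Nc2cc(C)nc3ccccc23)cc1`: 22000 nM
Compound 2 `Cc1cc(NC(=O)Nc2ccc(O)cc2)c2ccccc2n1`: > 25000 nM (a limit)
Compound 3 `Cc1cc(NC(=O)Nc2ccc(SC(F)(F)F)cc2)c2ccccc2n1`: > 25000 nM (a limit)

In an ADME assay on BJ cells (Homo sapiens) for cytotoxicity, with a stated time of 72 h (on this read-out higher numbers stand for an effect only at larger amounts of compound and lower numbers for an effect already at smaller amounts), compound 3 gives > 25000 nM as a limit, not a number. That places it at the limit of > 25000 nM in this assay, at which 2 of the 3 values shown sit, and no exact value is known. Compound 4 `Cc1cc(NC(=O)Nc2ccc(N)cc2)c2ccccc2n1` carries amino in place of (trifluoromethyl)sulfanyl on an aromatic carbon. The measured swaps at that place give only floors or nothing readable: (an at least 1.1-fold higher number from compound 1 to compound 2 (0.05 log units; that floor lies within the scatter)), (an at least 1.1-fold higher number from compound 1 to compound 3 (0.05 log units; that floor lies within the scatter)) and (a step that the two limits leave unreadable from compound 2 to compound 3). No step beyond the scatter, in either direction, is therefore expected, and the estimated step is an at least 1.0-fold lower number from compound 3 to compound 4 (0.01 log units; that floor lies within the scatter) in this assay by this reading. For compound 4 the estimate is 24000 nM (expected range 11000 nM to 45000 nM) and a report as a limit is quite likely.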

Compound 4, half-maximal effective concentration: > 25000 nM
Compound 4 was reported as a limit (the forecaster's own chance of this, stated with the estimate: 60%); at least 1.0-fold (0.01 log units) between middle value and limit.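

With amino, a third group at this place joins the limit of this assay, so compound 4 also gives a limit and not a number: the limit of > 25000 nM in this assay, at which 3 of the 4 values shown sit.

Among the compounds shown here, the only readable new step is an at least 1.1-fold higher number from compound 1 to compound 4 (0.05 log units; that floor lies within the scatter). The steps linking compound 4 with compound 2 and compound 3 cannot be read.

On these data alone, it remains open how far above the limit these compounds lie, and whether they differ from one another at all. Also open, as far as these compounds go, is whether a carboxylic acid or a methoxy group at this place would give a number in this assay.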